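A Fluorine Swap on an Inactive Compound

The source may hold more compounds than are shown below. What is called first, only, known or untested is meant among the compounds shown, and "the series" means these compounds.

So far two compounds have been tested in a functional assay on MCF7 cells (Homo sapiens) for cytotoxicity, read by MTT assay, with a stated time of 48 h; on this read-out lower numbers stand for stronger inhibition and higher numbers for weaker inhibition. Compound 1 (`COc1cc(NC(=O)n2cc(-c3ccc(O)cc3)n(-c3cc(OC)c(OC)c(OC)c3)c2=O)cc(OC)c1OC`) gives > 50000 nM, which is a limit and not a number. Compound 2 (`COc1cc(-n2c(-c3ccccc3)cn(C(C)=O)c2=O)cc(OC)c1OC`) gives > 50000 nM, also a limit. Compound 2 therefore has no exact value, and its place is the limit of > 50000 nM in this assay, at which 2 of the 2 values shown sit. Compound 3 (`COc1cc(-n2c(-c3ccc(F)cc3F)cn(C(C)=O)c2=O)cc(OC)c1OC`) differs from compound 2 by one change, 2,4-difluorophenyl in place of phenyl on an aromatic carbon. The expected change is small, towards stronger inhibition: an at least 1.2-fold lower number from compound 2 to compound 3 (0.09 log units; that floor lies within the scatter). For compound 3 the estimated value is 40000 nM, with an expected range from 5000 nM to 100000 nM.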

Compound 3, half-maximal inhibitory concentration: 49300 nM
Compound 3: middle estimate off by 1.2-fold (0.09 log units), on the low side, and the stated range covers the measured number.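

With 2,4-difluorophenyl in place of phenyl on this aromatic carbon, compound 3 gives 49300 nM, the first exact number shown. Its phenyl partner has only a limit, so the change can be read only as an at least 1.0-fold lower number from compound 2 to compound 3 (0.00 log units; that floor lies within the scatter), and no clear gain is shown. Most of the values shown still sit at one limit: the limit of > 50000 nM in this assay, at which 2 of the 3 values shown sit.

As far as these compounds go, it remains open whether an amine on that phenyl ring would shift the number beyond the scatter. A carboxylic acid in place of the acetyl group is equally untested among the compounds shown.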